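A few compounds are considered here, and "the series" means these few. Any claim that something is new, unique, unknown or untested is made for them only; others in the source may bear on it.

Compound 1, `CC#CCn1c(N2CCC[C@@H](N)C2)cc(=O)n(Cc2cc(C(=O)OC)ccc2Br)c1=O`, is known in an assay on isolated protein for inhibition of Dipeptidyl peptidase 9 (Homo sapiens), read by fluorescence, with stated times of 15 min and 20 min (a higher number here means a weaker inhibitor, a lower number a stronger inhibitor), only through a limit: compound 1 gives > 100 nM, which is a limit of the assay and not a number. Its companion compound 2, `CC#CCn1c(N2CCC[C@@H](N)C2)cc(=O)n(Cc2cc(C(=O)O)ccc2Br)c1=O`, differs by hydrogen in place of methyl on an oxygen next to a carbonyl group. In this assay compound 2 also gives > 100 nM, again a limit. Going by the values given here, the step that the two limits leave unreadable from compound 1 to compound 2 therefore cannot be read, and this is the only measured step available; it rests on (the limit of > 100 nM in this assay, at which 2 of the 2 values shown sit).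

The unmeasured compound 3, `CC#CCn1c(N2CCC[C@@H](N)C2)cc(=O)n(Cc2cc(C(=O)OC)ccc2F)c1=O`, differs from compound 1 by fluoro in place of bromo on an aromatic carbon. Among the compounds with values here, no measured step touches this position, and the single step that is known is unreadable, so nothing here points in either direction for the halogen exchange. The estimate for compound 3 in this assay therefore starts from the limit of compound 1 and assumes no change beyond the usual scatter: compound 3 is expected at 300 nM, within a range from 100 nM to 3000 nM. This expectation means a step that the limit leaves unreadable from compound 1 to compound 3, with a real chance that only a limit is reported again.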

Compound 3, half-maximal inhibitory concentration: > 100 nM
Compound 3 gave a limit, no number; the forecaster's own chance of this, stated with the estimate: 60%; the middle value does not contradict the limit.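

In this assay compound 3 gives > 100 nM, a limit of the assay and not a number, so no step from compound 1 to compound 3 can be read: the limit of > 100 nM in this assay, at which 3 of the 3 values shown sit.

As far as these compounds go, the actual strengths of compound 1, compound 2 and compound 3 stay open, as does whether fluoro and bromo differ at all in this assay.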